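Carboxy in place of hydroxymethyl on the shared core

A few compounds are considered here, and "the series" means these few. Any claim that something is new, unique, unknown or untested is made for them only; others in the source may bear on it.

Measured compounds in a functional assay on Z-138 cells (Homo sapiens) for inhibition, read by luminescence and CellTiter-Glo, with a stated time of 72 h; a higher number here means a weaker inhibitor, a lower number a stronger inhibitor:
Compound 1 `C=CC(=O)Nc1ccc(Cn2nc(-c3ccc(Oc4ccccc4)cc3)cc2C(=O)O)cc1` gives > 60000 nM, which is a limit of this assay rather than a number.
Compound 2 `C/C=C/C(=O)Nc1cccc(Cn2nc(-c3ccc(Oc4ccccc4)cc3)cc2C(=O)O)c1` gives 24100 nM.
Compound 3 `C=CC(=O)Nc1cccc(Cn2nc(-c3ccc(Oc4ccccc4)cc3)cc2CO)c1` gives 6000 nM.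

Among the two numbers shown, compound 3 stands lowest, so it is the stronger inhibitor of the pair; compound 2 sits a step above it that lies beyond the scatter, and the remaining entry for compound 1 is a limit only (the limit of > 60000 nM in this assay, at which 1 of the 3 values shown sits). Compound 4 `C=CC(=O)Nc1cccc(Cn2nc(-c3ccc(Oc4ccccc4)cc3)cc2C(=O)O)c1` is not yet measured. It differs from compound 3 in one place: carboxy in place of hydroxymethyl on an aromatic carbon. Among the measured compounds shown here, compound 4 shares its carboxy with compound 2 and compound 1, and both of those show higher numbers than compound 3, though neither pair differs from compound 4 in this one place alone, so no step between measured compounds can be read off. The step from compound 3 to compound 4 is expected to be a moderate move toward a weaker inhibitor, beyond the scatter, written as a 2.2-fold higher number from compound 3 to compound 4 (0.34 log units; beyond the scatter). Compound 4 is therefore estimated at 13000 nM in this assay, with a range from 4500 nM to 40000 nM.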

Compound 4, half-maximal inhibitory concentration: 28500 nM
For compound 4 the middle estimate is 2.2-fold (0.34 log units) below the measured one; measured number inside the range.
By their numbers in this assay, from the lowest: compound 3; then compounds 2 and 4 (each within the scatter of the next). At a limit, above all of these: compound 1.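

In this assay, the exchange of hydroxymethyl for carboxy on the aromatic carbon next to the ring nitrogen can now be read on its own, as a 4.8-fold higher number from compound 3 to compound 4 (0.68 log units; beyond the scatter), so at this position the hydroxymethyl compound gives the lower number and the change alone is enough to shift the read-out beyond the scatter. With carboxy held in place, vinyl in place of prop-1-en-1-yl on the carbonyl carbon amounts to a 1.2-fold higher number from compound 2 to compound 4 (0.07 log units; within the scatter), so the two carboxy compounds cannot be ordered and that change shows no effect here. The exchange of 4-((vinylcarbonyl)amino)phenyl for 3-((vinylcarbonyl)amino)phenyl reads as an at least 2.1-fold lower number from compound 1 to compound 4 (0.32 log units; beyond the scatter), a step that gives only a minimum size, as compound 1 stands at a limit and not at a number: the limit of > 60000 nM in this assay, at which 1 of the 4 values shown sits.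

The compounds shown leave open whether a methyl ester, a primary amide or an aminomethyl group on this same carbon would fall nearer compound 3 or compound 4. They also leave open how prop-1-en-1-yl or the 4-((vinylcarbonyl)amino)phenyl group would read with hydroxymethyl in place of carboxy.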